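Swapping a nitro for a chloro on the aryl thiosemicarbazone

The compounds below may be only part of what the source reports. "The series", "measured", "known", "first", "only" and "open" are said of these compounds alone.

Three compounds sharing one core were tested in a functional assay on T98G cells (Homo sapiens) for cytotoxicity, read by MTT assay, with a stated time of 48 h; a higher number here means a weaker inhibitor, a lower number a stronger inhibitor. Compound 1 `C/C(=N\NC(=S)Nc1ccc(Cl)cc1)c1ccccn1` gives 5.9 nM, compound 2 `C/C(=N/NC(=S)Nc1ccccc1[N+](=O)[O-])c1ccccn1` gives 6.61 nM, and compound 3 `C/C(=N\NC(=S)Nc1ccc([N+](=O)[O-])cc1)c1ccccn1` gives 140 nM. Compound 1 and compound 3 differ in a single place, (chloro in place of nitro on an aromatic carbon), and that one change produced a 24-fold lower number from compound 3 to compound 1 (1.38 log units; beyond the scatter). Compound 2 and compound 3 are built from the same atoms joined differently; the difference between their two cores is not broken down here, and their values simply stand as they are.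

Compound 4 `C/C(=N/NC(=S)Nc1ccccc1Cl)c1ccccn1` has not yet been measured in this assay. It comes from compound 2 by chloro in place of nitro on an aromatic carbon, the same kind of change as from compound 3 to compound 1, though the place differs: in compound 4 the chloro sits ortho to a large group, in compound 1 para to a large group. Because compound 2 already gives 6.61 nM, close to compound 1, a drop as large as a 24-fold lower number from compound 3 to compound 1 (1.38 log units; beyond the scatter) seems unlikely to repeat; the expected step is a 1.7-fold lower number from compound 2 to compound 4 (0.22 log units; within the scatter). Compound 4 is therefore estimated at 4 nM, between 1.2 nM and 15 nM.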

Compound 4, half-maximal inhibitory concentration: 1.1 nM
Compound 4: the middle estimate sits 3.6-fold (0.56 log units) above what was measured, and the stated range ends above it.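

In this assay, chloro in place of nitro again lowered the number, with a 6.0-fold lower number from compound 2 to compound 4 (0.78 log units; beyond the scatter), so the direction of the change held on the second core. Its size did not hold, and the two steps differ by more than repeated measurements would explain: the same change on two cores in this assay, a 24-fold lower number (1.38 log units; beyond the scatter) from compound 3 to compound 1 and a 6.0-fold lower number (0.78 log units; beyond the scatter) from compound 2 to compound 4, 3.9-fold (0.60 log units) apart, beyond the scatter of two such steps. Going by these compounds alone, this shows that the gain from this swap cannot simply be copied from one core to another, but with only two pairs it does not show why the steps differ, or whether the swap would lower the number on any further core.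

In compound 4 the chloro sits ortho to a large group, but the compounds shown do not separate the effect of that place from the effect of the rest of the core. Going by these compounds, it also remains open how an amine, a methoxy group or a carboxylic acid on the same aromatic carbon would compare with chloro and nitro.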